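Shortening the ester chain on the core of compound 1

The source may hold more compounds than are shown below. What is called first, only, known or untested is meant among the compounds shown, and "the series" means these compounds.

Compound 1 `COC(=O)CCCc1onc(NS(=O)(=O)c2ccc(C(C)(C)C)cc2)c1Sc1cccc(OC)c1` gives 400 nM in an assay on A7R5 cells for displacement of a labelled ligand from Endothelin-1 receptor (Rattus norvegicus) (on this read-out lower numbers stand for stronger inhibition and higher numbers for weaker inhibition), the lowest of the three numbers measured, though compound 2 sits within the scatter of it. Compound 2 `COc1cccc(Sc2c(NS(=O)(=O)c3ccc(C(C)(C)C)cc3)noc2C)c1` gives 530 nM in this assay. That step reads a 1.3-fold higher number from compound 1 to compound 2 (0.12 log units; within the scatter). Compound 3 `COc1cccc(Sc2c(NS(=O)(=O)c3ccc(C(C)(C)C)cc3)noc2CO)c1` gives 6200 nM in this assay, and the steps of a 16-fold higher number from compound 1 to compound 3 (1.19 log units; beyond the scatter) and a 12-fold higher number from compound 2 to compound 3 (1.07 log units; beyond the scatter) are both large. Compound 4 `COc1cccc(Sc2c(NS(=O)(=O)c3ccc(C(C)(C)C)cc3)noc2CCC=O)c1` differs from compound 1 by formyl in place of (methoxycarbonyl)methyl on a saturated chain carbon, two bonds along the chain from an aromatic carbon. Of the measured steps, the removal of the whole chain, a 1.3-fold higher number from compound 1 to compound 2 (0.12 log units; within the scatter), bears most closely, and no hydroxy enters compound 4. Compound 4 is therefore expected to stand near compound 1, with a 1.3-fold higher number from compound 1 to compound 4 (0.10 log units; within the scatter) within the scatter. Compound 4 is estimated at 500 nM, with a range from 200 nM to 1500 nM.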

Compound 4, half-maximal inhibitory concentration: 380 nM
Compound 4: the middle estimate sits 1.3-fold (0.12 log units) above what was measured; low and high end bracket the measured number.
By their numbers in this assay, from the lowest: compounds 4, 1 and 2 (each within the scatter of the next); then compound 3.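

In this assay, the 2-formylethyl chain does as well as the 3-(methoxycarbonyl)propyl chain, a 1.1-fold lower number from compound 1 to compound 4 (0.02 log units; within the scatter), so the methyl ester end is not needed to hold the number at this position. The formyl-ended chain also matches the bare methyl of compound 2, a 1.4-fold lower number from compound 2 to compound 4 (0.14 log units; within the scatter), while the large loss with hydroxy does not carry over to it, a 16-fold lower number from compound 3 to compound 4 (1.21 log units; beyond the scatter). Nothing available explains these results.

On these data alone, it remains open whether a carboxylic acid or an amine at the chain end would behave the same way. As far as these compounds go, it is also open whether a longer chain ending in hydroxy would show the loss seen in compound 3.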